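The source may report more compounds than this note shows. Statements on the series, on what has been measured and on what is new or still open speak of the compounds shown alone.

Three diaryl ureas built on one shared core were tested in an ADME assay on WI-38 cells (Homo sapiens) for cytotoxicity, read by MTT assay, with a stated time of 72 h; a higher number here means a weaker inhibitor, a lower number a stronger inhibitor. Compound 1 `Cn1ncnc1-c1cc(Oc2ccc(NC(=O)Nc3cccc(C(F)(F)F)c3)cc2F)ccn1` gives 22400 nM in this assay. Compound 2 `Cn1cnnc1-c1cc(Oc2ccc(NC(=O)Nc3cccc(C(F)(F)F)c3)cc2F)ccn1` gives 12600 nM in this assay, a shift of a 1.8-fold lower number from compound 1 to compound 2 (0.25 log units; within the scatter). Compound 3 `CCN(CC)CCn1cnnc1-c1cc(Oc2ccc(NC(=O)Nc3cccc(C(F)(F)F)c3)cc2F)ccn1` gives 6920 nM in this assay. Compound 3 therefore holds the lowest of the three numbers, but only a 3.2-fold lower number from compound 1 to compound 3 (0.51 log units; beyond the scatter) lies beyond the scatter, while a 1.8-fold lower number from compound 2 to compound 3 (0.26 log units; within the scatter) does not, so compound 3 and compound 2 cannot be told apart on these values.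

Compound 4 `CCN(CC)CCn1cnnc1-c1cc(Oc2ccc(NC(=O)Nc3ccc(F)c(Cl)c3)cc2F)ccn1` is the next member. It keeps the side of compound 3 that carries the 2-(diethylamino)ethyl group and instead alters the other end of the urea: 3-chloro-4-fluorophenyl in place of 3-(trifluoromethyl)phenyl on an amide-type nitrogen. Going by the values given here, none of the three measured steps touches this part of the molecule; all of them vary the group on the opposite end, so no measured step bears directly on the change from compound 3 to compound 4. With nothing to suggest movement in either direction, compound 4 is expected to land close to compound 3, with a step of a 1.0-fold higher number from compound 3 to compound 4 (0.00 log units; within the scatter) that stays within the scatter. The estimate for compound 4 is 7000 nM, with a likely range from 2500 nM to 20000 nM.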

Compound 4, half-maximal inhibitory concentration: 28700 nM
Compound 4: the middle estimate sits 4.1-fold (0.61 log units) below what was measured, and the stated range ends below it.
By their numbers in this assay, from the lowest: compounds 3, 2, 1 and 4 (each within the scatter of the next, the first and the last beyond it).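

In this assay, the end of the urea that carries the aryl group on the amide-type nitrogen proves to be a position that matters: 3-chloro-4-fluorophenyl in place of 3-(trifluoromethyl)phenyl gives a 4.1-fold higher number from compound 3 to compound 4 (0.62 log units; beyond the scatter) and so lies beyond the scatter. Going by these compounds alone, the earlier steps all varied the opposite end, and only one of them, a 3.2-fold lower number from compound 1 to compound 3 (0.51 log units; beyond the scatter), cleared the scatter, so this single exchange on the other side of the urea is the first sign that the number also responds to the aryl group while the 2-(diethylamino)ethyl group stays fixed. No measured evidence here accounts for this step.

The compounds shown leave open whether a plain phenyl, a 3-chlorophenyl or a 4-fluorophenyl on that nitrogen would stay near compound 3 or near compound 4, so the step cannot yet be divided between the chlorine, the fluorine and the loss of the trifluoromethyl group. They also leave open whether the same exchange gives a similar step with the methyl group of compound 2 on the other end, or with a morpholine in place of the diethylamino group.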